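Moving the Chlorine Around the Benzoyl Ring

A few compounds are considered here, and "the series" means these few. Any claim that something is new, unique, unknown or untested is made for them only; others in the source may bear on it.

Measured compounds:
compound 1 `O=C(Nc1ccc(C(F)(F)F)cc1)N1CCOC2(CCN(C(=O)c3ccccc3)CC2)C1`: 63 ug/mL
compound 2 `O=C(Nc1ccc(C(F)(F)F)cc1)N1CCOC2(CCN(C(=O)c3ccccc3Cl)CC2)C1`: 12 ug/mL

In an ADME assay for solubility, in simulated intestinal fluid (a higher number here means a more soluble compound, a lower number a less soluble compound), compound 1 gives 63 ug/mL, while compound 2 gives 12 ug/mL, the lowest of the two numbers. For the measured compounds named here, the only measured step is a 5.3-fold lower number from compound 1 to compound 2 (0.72 log units; beyond the scatter), which adds a chlorine rather than moving one. Compound 3 `O=C(Nc1ccc(C(F)(F)F)cc1)N1CCOC2(CCN(C(=O)c3cccc(Cl)c3)CC2)C1` differs from compound 2 by 3-chlorophenyl in place of 2-chlorophenyl on a carbonyl carbon. Going by the values given here, no measured step shifts a chlorine to a different place on the same ring, so that step bears only loosely here; the shift is expected to stay within the scatter, with a 1.2-fold lower number from compound 2 to compound 3 (0.08 log units; within the scatter). Compound 3 is estimated at 10 ug/mL, between 3 ug/mL and 30 ug/mL.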

Compound 3, solubility: 21 ug/mL
Estimate against measurement, compound 3: 2.1-fold (0.32 log units) below; low and high end bracket the measured number.
By their numbers in this assay, from the lowest: compounds 2 and 3 (each within the scatter of the next); then compound 1.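

In this assay, shifting the chlorine gives a 1.8-fold higher number from compound 2 to compound 3 (0.24 log units; within the scatter) and so leaves 2-chlorophenyl and 3-chlorophenyl indistinguishable at this carbonyl carbon. Chloro in place of hydrogen gives a 3.0-fold lower number from compound 1 to compound 3 (0.48 log units; beyond the scatter) as well, so the drop seen with compound 2 is not confined to the 2-chlorophenyl placement, though it rests on just these two compounds. Nothing available explains these numbers. On these data alone, what a methoxy group, an amine or a carboxylic acid in place of the chlorine would do to this number remains open.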